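Compound 4: 4-Hydroxybenzyl in Place of 4-Methoxyphenyl

The source may hold more compounds than are shown below. What is called first, only, known or untested is meant among the compounds shown, and "the series" means these compounds.

Three compounds have been measured in an assay on CHO cells for displacement of a labelled ligand from adenosine receptor A3 (Homo sapiens), read by scintillation counting, tested at 1 uM; a lower number here means less inhibition, a higher number more inhibition at the concentration tested (going by the name of the read-out):

- compound 1, `COc1ccc(Cc2nc(N)c3nn(-c4ccccc4)cc3n2)cc1`, gives 38%
- compound 2, `Nc1nc(Cc2ccccc2Cl)nc2cn(-c3ccccc3)nc12`, gives 22%
- compound 3, `Nc1nc(CCc2ccccc2)nc2cn(-c3ccccc3)nc12`, gives 17%

Compound 1 stands highest of the three. Compound 2 is nearest to it, with a drop of a number 16 percentage points lower from compound 1 to compound 2 (beyond the scatter), and compound 3 is furthest, with a drop of a number 21 percentage points lower from compound 1 to compound 3 (beyond the scatter). Between compound 2 and compound 3 the difference is a number 5 percentage points lower from compound 2 to compound 3 (within the scatter), so those two cannot be told apart.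

Compound 4, `Nc1nc(CCc2ccc(O)cc2)nc2cn(-c3ccccc3)nc12`, has not yet been measured in this assay. It differs from compound 1 in one place: 4-hydroxybenzyl in place of 4-methoxyphenyl on a saturated chain carbon bound to an aromatic carbon

The step from compound 1 to compound 3 bears most directly on this change, since in both cases the 4-methoxyphenyl group is replaced by a benzyl-type group on the same saturated chain carbon; that step was a number 21 percentage points lower from compound 1 to compound 3 (beyond the scatter). The step from compound 1 to compound 2 points the same way, at a number 16 percentage points lower from compound 1 to compound 2 (beyond the scatter). Both replacements of the 4-methoxyphenyl group so far have lowered the read-out beyond the scatter.

Compound 4 is therefore expected to sit below compound 1, with an estimated step of a number 18 percentage points lower from compound 1 to compound 4 (beyond the scatter). The estimate for compound 4 is 20%, in a range from 5% to 38%.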

Compound 4, a percentage reported as inhibition, at one concentration (the size of the read-out at that concentration, not a potency): 37%
Beside the measured number, compound 4's estimate is 17 percentage points below it; the range from low to high includes it.
By their numbers in this assay, from the lowest: compounds 3 and 2 (each within the scatter of the next); then compounds 4 and 1 (each within the scatter of the next).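

In this assay, among these compounds, 4-hydroxybenzyl in place of 4-methoxyphenyl on a saturated chain carbon bound to an aromatic carbon is the first replacement at this position that leaves the read-out unchanged within the scatter, the step being a number 1 percentage points lower from compound 1 to compound 4 (within the scatter), so replacing the 4-methoxyphenyl group does not in itself lower the number. Among the compounds shown here, the single change of hydroxy in place of hydrogen on an aromatic carbon gives a number 20 percentage points higher from compound 3 to compound 4 (beyond the scatter), and 4-hydroxybenzyl in place of 2-chlorophenyl gives a number 15 percentage points higher from compound 2 to compound 4 (beyond the scatter), which shows that the benzyl-type group at this position can read as high as the 4-methoxyphenyl group once it carries the hydroxy. Nothing available explains why the hydroxy group has this effect on the read-out.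

The compounds shown leave open whether an amine or a carboxylic acid in place of the hydroxy would hold the number at this level, and whether a longer chain carrying the hydroxy-bearing ring would do the same. Since each compound is read at a single concentration, they also leave open how compound 1 and compound 4 compare in potency.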